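The source may report more compounds than this note shows. Statements on the series, on what has been measured and on what is new or still open speak of the compounds shown alone.

Working notes on the seleno series in a functional assay on HTB-54 cells (Homo sapiens) for cytotoxicity, read by MTT assay, with a stated time of 72 h; on this read-out lower numbers stand for stronger inhibition of growth and higher numbers for weaker inhibition of growth. Compound 1 `[SeH]c1nc([SeH])c2ccccc2n1` gives 5980 nM in this assay. Compound 2 `Nc1nc([SeH])nc2ncccc12` gives 44300 nM in this assay. Compound 3 `C[Se]c1nc([Se]C)c2cccnc2n1` gives "not determined" (no result reported) in this assay: nothing was determined for it, so compound 3 stands nowhere on the numbers shown and offers no anchor of its own. Compound 4 `C[Se]c1nc(N)c2cccnc2n1` is the next member to be measured in this assay; it differs from compound 3 in one place, (one nitrogen atom in place of a group of 2 heavy atoms (1 carbon, 1 selenium; no ring), on an aromatic carbon). Within the data shown here, with no number for compound 3, no step from compound 3 to compound 4 can be computed; whatever is said about compound 4 rests on compound 1 and compound 2 alone. Compound 4 carries the amino group that compound 2 also carries, together with one group of 2 heavy atoms of the kind found twice in compound 3. In this assay the change is expected to bring a step of modest size, if any, toward weaker inhibition of growth, and it may well stay within the scatter. Compound 4 is expected to give about 20000 nM in this assay, with an estimated range from 4000 nM to 100000 nM. This estimate leans on compound 2 at 44300 nM and on compound 1 at 5980 nM.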

Compound 4, concentration for 50% growth inhibition: 78200 nM
Estimate against measurement, compound 4: 3.9-fold (0.59 log units) below, within the range that was stated.
By their numbers in this assay, from the lowest: compound 1; then compounds 2 and 4 (each within the scatter of the next).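

In this assay, among these compounds, the step of a 1.8-fold higher number from compound 2 to compound 4 (0.25 log units; within the scatter) is the first that can be read between compounds differing in one place, and with the amino group kept, methyl in place of hydrogen on a selenium leaves the two numbers inseparable on this read-out. The step from compound 3 to compound 4, with amino entering on an aromatic carbon in place of the group of 2 heavy atoms, cannot be read: compound 3 has no number, so this result says nothing directly about that exchange at this position. Nothing on hand gives a measured reason for what is seen at the selenium.

Going by these compounds, whether a longer chain on the selenium, such as ethyl or propyl, would stay within the scatter or move the number beyond it remains open. Also open, on these data alone, is what a carboxylic acid or a dimethylamino group would do in place of the amino group on the shared core.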